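A Fluorine Added to the Phenyl Ring of Compound 1

A few compounds are considered here, and "the series" means these few. Any claim that something is new, unique, unknown or untested is made for them only; others in the source may bear on it.

Compound 1 `CC1CC(=O)N(CC(=O)N2CCN(c3ccccc3)CC2)C1=O` was tested in a functional assay on the whole organism (strain CD1) with Mus musculus as the target, in the maximal electroshock model, with a stated time of 0.5 h (a lower number here means that less compound is needed, a higher number that more compound is needed for the effect), where compound 1 gives 300 mg/kg. Of the two compounds measured, compound 1 stands at the higher end: compound 2 `CCC1(C)CC(=O)N(CC(=O)N2CCN(c3ccccc3C)CC2)C1=O` differs from it in several places, and in this assay compound 2 gives 100 mg/kg, a lower number that lies beyond the usual scatter. Compound 3 `CC1CC(=O)N(CC(=O)N2CCN(c3ccccc3F)CC2)C1=O` has not yet been measured. It differs from compound 1 in one place: fluoro in place of hydrogen on an aromatic carbon. The fluoro enters on an aromatic carbon of the six-membered aromatic ring of carbon only, ortho to a large group, so the change reads phenyl to 2-fluorophenyl. Within the data shown here, no measured pair shows this exact change, so its effect is not known from these data. Compound 3 is expected to move modestly toward a lower number, an estimated step of a 1.5-fold lower number from compound 1 to compound 3 (0.18 log units; within the scatter). In this assay compound 3 is estimated at 200 mg/kg, within a range from 100 mg/kg to 400 mg/kg.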

Compound 3, minimum effective dose: 300 mg/kg
Beside the measured number, compound 3's estimate is 1.5-fold (0.18 log units) below it; measured number inside the range.
By their numbers in this assay, from the lowest: compound 2; then compounds 1 and 3 (each within the scatter of the next).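

Among these compounds, changing phenyl to 2-fluorophenyl brings no change at the digits printed from compound 1 to compound 3 (within the scatter) in this assay and gives the first reading of a single change, since the two earlier compounds differ in several places and tie no effect to any one of them. On this aromatic carbon, ortho to a large group, one fluoro in place of hydrogen leaves the minimum effective dose within the usual scatter, so this single swap gives no sign of an effect on the dose needed. Nothing at hand explains why the dose stays level.

As far as these compounds go, it remains open whether a different group on this same carbon, such as chloro, methoxy or trifluoromethyl, would leave the dose as level as fluoro does. Also open, from the compounds shown here alone, is whether fluoro on another carbon of the phenyl ring, or an amine there, would shift it.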